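Swapping the pyridine for a phenyl on the amine

This account rests on a few compounds, and the source may have more. Where it says the series, first, only, none or still open, it means among the compounds named here.

Compound 1 `Cc1ccnc(NC(c2ccccc2)c2ccc3cccnc3c2O)c1` has been tested in an assay for inhibition of protein disulfide-isomerase (Homo sapiens), with a stated time of 1 h; on this read-out lower numbers stand for stronger inhibition and higher numbers for weaker inhibition. In that assay compound 1 gives < 200 nM, which is a limit of the assay and not a number. Among the measured compounds shown here, compound 2 `Cc1ccnc(NC(c2cccc(F)c2)c2ccc3cccnc3c2O)c1` is the only other measured compound, and in this assay compound 2 gives 350 nM. For the measured compounds named here, the one measured step, an at least 1.7-fold higher number from compound 1 to compound 2 (0.24 log units; that floor lies within the scatter), concerns a different part of the molecule. Compound 3 `Oc1c(C(Nc2ccccc2)c2ccccc2)ccc2cccnc12` is not yet measured; it differs from compound 1 by phenyl in place of 4-methylpyridin-2-yl on an amine nitrogen. Going by the values given here, no measured step bears on this change, so the expectation rests on the change alone. For compound 3 the estimate in this assay is 600 nM, with a range from 150 nM to 2500 nM. The expected step is an at least 3.0-fold higher number from compound 1 to compound 3 (0.47 log units; beyond the scatter), a weakening.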

Compound 3, half-maximal inhibitory concentration: 110 nM
The estimate for compound 3 lay 5.5-fold (0.74 log units) above the measured number, outside the stated range (below it).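

No size can be read for the step between compound 1 and compound 3, because the value of compound 1 is a limit of the assay and not a number: the limit of < 200 nM in this assay, at which 1 of the 3 values shown sits.

In this assay the compounds shown leave open how large the difference is between phenyl and 4-methylpyridin-2-yl on this amine nitrogen.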